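Replacing dimethylamino with azido on the shared core

The compounds below may be only part of what the source reports. "The series", "measured", "known", "first", "only" and "open" are said of these compounds alone.

Compounds measured so far:
Compound 1, `O=C(CCn1cnc2ccccc21)N/N=C/c1c(O)ccc2ccccc12`: 30000 nM
Compound 2, `CN(C)Cc1nc2ccccc2n1CCC(=O)N/N=C/c1c(O)ccc2ccccc12`: 90000 nM

Of the compounds shown here, two that share one core have been measured in a physicochemical assay for solubility, read by fluorescence and spectrophotometry; on this read-out lower numbers stand for lower solubility and higher numbers for higher solubility. Compound 1 gives 30000 nM in this assay, and compound 2 gives 90000 nM. Among the measured compounds shown here, the one step between them, a 3.0-fold higher number from compound 1 to compound 2 (0.48 log units; beyond the scatter), is the only measured step and it puts compound 2 at the higher of the two numbers.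

Compound 3, `[N-]=[N+]=NCc1nc2ccccc2n1CCC(=O)N/N=C/c1c(O)ccc2ccccc12`, has not yet been measured. It differs from compound 2 by azido in place of dimethylamino on a saturated chain carbon bound to an aromatic carbon. For the measured compounds named here, the change removes the very group whose arrival made the measured step, so that step is the only guide: if the gain of compound 2 over compound 1 rests on the dimethylamino group, taking it away should give it back, and the azido group that enters has no measured counterpart here. A step downward from compound 2, about the size of the measured step, is therefore expected, with wide uncertainty because the azido group is new to this set. Compound 3 is estimated at 30000 nM, in the range 10000 nM to 90000 nM, meaning an expected step of a 3.0-fold lower number from compound 2 to compound 3 (0.48 log units; beyond the scatter).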

Compound 3, solubility: 20000 nM
Compound 3: middle estimate off by 1.5-fold (0.18 log units), on the high side; the measured number falls inside the stated range.
By their numbers in this assay, from the lowest: compounds 3 and 1 (each within the scatter of the next); then compound 2.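

In this assay the saturated chain carbon bound to an aromatic carbon now carries a second measured group, and azido in place of dimethylamino gives a 4.5-fold lower number from compound 2 to compound 3 (0.65 log units; beyond the scatter) and so shows that the number of compound 2 does not hold for every group placed there. Set against the hydrogen of compound 1, the azidomethyl group gives a 1.5-fold lower number from compound 1 to compound 3 (0.18 log units; within the scatter) and leaves compound 3 and compound 1 indistinguishable on this read-out, so of the two groups tried on that aromatic carbon only (dimethylamino)methyl, in compound 2, stands clear of compound 1. No accompanying measurement bears on why dimethylamino and azido part ways at this position.

The three compounds cannot say whether the higher number belongs to dimethylamino alone or would also appear with another amine on the same carbon, such as a primary amine, a morpholine or a piperidine. They also leave open how a hydroxyl or a carboxylic acid would read at this position, and whether a longer chain carrying the dimethylamino group would keep the step seen for compound 2.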